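Boron-nitrogen chelate series: bromo replaces the phenyl

The source may report more compounds than this note shows. Statements on the series, on what has been measured and on what is new or still open speak of the compounds shown alone.

Readings come from an assay on HEK293 cells for inhibition of transient receptor potential cation channel subfamily V member 6 (Homo sapiens), read by FLIPR and calcium flux, with a stated time of 5 min; on this read-out lower numbers stand for stronger inhibition and higher numbers for weaker inhibition. Compound 1 `Cc1ccc([B-]2(c3ccccc3)[NH2+]CCO2)cc1` gives 18900 nM. For the measured compounds named here, compound 2 `c1ccc(-c2ccc([B-]3(c4ccccc4)[NH2+]CCO3)cc2)cc1` gives 72300 nM, the highest of the two numbers so far, with compound 1 nearest at a lower number. Compound 3 `Brc1ccc([B-]2(c3ccccc3)[NH2+]CCO2)cc1` carries bromo in place of phenyl on an aromatic carbon, on the aromatic carbon para to a large group. Going by the values given here, only one measured step bears on this: a 3.8-fold higher number from compound 1 to compound 2 (0.58 log units; beyond the scatter), a modest rise when phenyl entered. Removing that phenyl again is expected to undo part of it. The step is estimated at a 2.9-fold lower number from compound 2 to compound 3 (0.46 log units; beyond the scatter). Compound 3 is therefore estimated at 25000 nM, within 9000 nM to 70000 nM.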

Compound 3, half-maximal inhibitory concentration: 13200 nM
For compound 3 the middle estimate is 1.9-fold (0.28 log units) above the measured one; measured number inside the range.
By their numbers in this assay, from the lowest: compounds 3 and 1 (each within the scatter of the next); then compound 2.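

Replacing phenyl with bromo on this aromatic carbon gives a 5.5-fold lower number from compound 2 to compound 3 (0.74 log units; beyond the scatter), so the phenyl of compound 2 stands apart from both smaller groups at this place. Bromo and methyl cannot be separated here, with a 1.4-fold lower number from compound 1 to compound 3 (0.16 log units; within the scatter). Nothing available explains why phenyl differs from the other two groups. From the compounds shown here alone, how an amine, a carboxylic acid or a nitrile would read at this place remains open. Also open, going by these compounds, is whether any group here can give a number clearly lower than those of compound 1 and compound 3.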